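The compounds below may be only part of what the source reports. "The series", "measured", "known", "first", "only" and "open" are said of these compounds alone.

Three compounds share one core and differ only in the group on an aromatic carbon. Compound 1 `CCCC(Oc1ccc(-n2cc(C(=O)N(C)C)cn2)cc1)c1ccc(C(=O)NCCC(=O)O)cc1` carries a dimethylcarbamoyl on its five-membered aromatic ring, and in a functional assay on cells for antagonist activity at Glucagon receptor (Homo sapiens), read by cAMP accumulation, in the presence of a further agent that is not named here (a lower number here means a stronger inhibitor, a higher number a weaker inhibitor), compound 1 gives only a limit, > 30000 nM. Compound 2 `CCCC(Oc1ccc(-n2cc(C#N)cn2)cc1)c1ccc(C(=O)NCCC(=O)O)cc1` carries a cyano instead, and in this assay compound 2 likewise gives only a limit, > 50000 nM. Within the data shown here, compound 3 `CCCC(Oc1ccc(-n2cc3c(n2)CCCC3)cc1)c1ccc(C(=O)NCCC(=O)O)cc1`, whose five-membered aromatic ring is fused to a six-membered non-aromatic ring of carbon only, gives in this assay 4200 nM, the only number among the three. The two steps onto compound 3 read an at least 7.1-fold lower number from compound 1 to compound 3 (0.85 log units; beyond the scatter) and an at least 11-fold lower number from compound 2 to compound 3 (1.07 log units; beyond the scatter).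

Compound 4 `CCCC(Oc1ccc(-n2cc(C(F)(F)F)cn2)cc1)c1ccc(C(=O)NCCC(=O)O)cc1` reverses that direction: a group of 9 heavy atoms (4 carbon, 2 nitrogen, 3 fluorine; one five-membered aromatic ring with 2 hetero atoms) in place of a group of 9 heavy atoms (7 carbon, 2 nitrogen; one five-membered aromatic ring with 2 hetero atoms, one six-membered non-aromatic ring of carbon only), on an aromatic carbon, so that a 4-(trifluoromethyl)-1H-pyrazol-1-yl stands where the fused rings stood. Both measured steps bear on this change, since both went from a singly substituted five-membered aromatic ring to the fused pair and both lowered the number well beyond the scatter. The reverse is therefore expected to raise the number in this assay, as a 3.6-fold higher number from compound 3 to compound 4 (0.55 log units; beyond the scatter), with a real chance that only a limit is reported. Compound 4 is estimated at 15000 nM, between 4000 nM and 60000 nM.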

Compound 4, antagonist equilibrium constant: 5100 nM
The estimate for compound 4 lay 2.9-fold (0.47 log units) above the measured number, within the range that was stated.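

In this assay, the fused rings of compound 3 prove not to be required for a measurable number, since the step to a single five-membered aromatic ring bearing trifluoromethyl reads a 1.2-fold higher number from compound 3 to compound 4 (0.08 log units; within the scatter), which leaves the two compounds indistinguishable. The earlier contrast between singly substituted and fused rings therefore does not hold as a rule, and the group on the five-membered aromatic ring matters: the steps read an at least 9.8-fold lower number from compound 2 to compound 4 (0.99 log units; beyond the scatter) and an at least 5.8-fold lower number from compound 1 to compound 4 (0.76 log units; beyond the scatter). Among these singly substituted compounds, trifluoromethyl alone gives a number rather than a limit.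

From the compounds shown here alone, compound 2 is reported only as a limit, so the steps from it give a minimum size and no more: the limit of > 50000 nM in this assay, at which 1 of the 4 values shown sits. Whether a methyl group, a chlorine atom or an amine on the five-membered aromatic ring would match compound 4 remains open.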